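Moving the Furan Oxygen on a Nucleoside Core

The source may report more compounds than this note shows. Statements on the series, on what has been measured and on what is new or still open speak of the compounds shown alone.

Compound 1 `Nc1nc(N)c2c(-c3ccccc3)cn([C@@H]3O[C@H](CO)[C@@H](O)[C@H]3O)c2n1` carries a phenyl group on the shared core. In a functional assay on CCRF-CEM cells (Homo sapiens), read by MTT assay, with a stated time of 72 h (on this read-out higher numbers stand for weaker inhibition and lower numbers for stronger inhibition), compound 1 reaches only the limit of the assay, > 20000 nM. Compound 2 `Nc1nc(N)c2c(-c3ccoc3)cn([C@@H]3O[C@H](CO)[C@@H](O)[C@H]3O)c2n1` has a furan-3-yl in place of that phenyl. Compound 2 likewise gives only a limit, > 20000 nM. The step that the two limits leave unreadable from compound 1 to compound 2 therefore cannot be sized, since both measurements sit at the limit of > 20000 nM in this assay, at which 2 of the 2 values shown sit. Compound 3 `Nc1nc(N)c2c(-c3ccco3)cn([C@@H]3O[C@H](CO)[C@@H](O)[C@H]3O)c2n1` is the next member, and its change from compound 2 is furan-2-yl in place of furan-3-yl on an aromatic carbon. Within the data shown here, the single measured step is the only one that bears on this change, and it offers no readable size, so no direction can be taken from it. The expected step is a step that the limit leaves unreadable from compound 2 to compound 3, meaning no change beyond the scatter. The estimate for compound 3 in this assay is 30000 nM, ranging from 10000 nM to 100000 nM, most likely again reported as a limit.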

Compound 3, half-maximal inhibitory concentration: > 20000 nM
Compound 3: no number, only a limit; the forecaster's own chance of this, stated with the estimate: 85%; the middle value does not contradict the limit.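

Compound 3 in this assay gives > 20000 nM, which is again only a limit, so the steps to compound 3 from compound 1 and from compound 2 cannot be read: the limit of > 20000 nM in this assay, at which 3 of the 3 values shown sit.

The compounds shown leave open whether phenyl, furan-3-yl and furan-2-yl differ at all in this assay.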